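This account rests on a few compounds, and the source may have more. Where it says the series, first, only, none or still open, it means among the compounds named here.

For the measured compounds named here, compound 2 `Cc1ccc(NC(=O)NC(=O)c2ccc(OCc3cccc(C(F)(F)F)c3)cc2)cc1-c1nc2ccccc2[nH]1` gives 9640 nM in a functional assay on SW-620 cells (Homo sapiens) for inhibition, read by MTT assay, with a stated time of 48 h (on this read-out higher numbers stand for weaker inhibition and lower numbers for stronger inhibition), the lower of the two numbers measured so far. Compound 1 `O=C(NC(=S)Nc1ccc(Cl)c(-c2nc3ccccc3[nH]2)c1)c1ccc(OCc2ccc(Cl)cc2Cl)cc1` gives 50200 nM in this assay. Compound 3 `Cc1ccc(NC(=O)NC(=O)c2ccc(OCc3ccc(F)cc3)cc2)cc1-c1nc2ccccc2[nH]1` has not yet been measured in this assay; it differs from compound 2 in one place: 4-fluorophenyl in place of 3-(trifluoromethyl)phenyl on a saturated chain carbon bound to an oxygen on an aromatic ring. Going by the values given here, no measured pair shows a swap of this kind, so only a small step is expected, in no clear direction beyond the scatter, a 1.2-fold higher number from compound 2 to compound 3 (0.10 log units; within the scatter). Compound 3 is therefore estimated at 12000 nM in this assay, with a range from 4000 nM to 40000 nM.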

Compound 3, half-maximal inhibitory concentration: 35100 nM
The estimate for compound 3 lay 2.9-fold (0.47 log units) below the measured number; the range from low to high includes it.
By their numbers in this assay, from the lowest: compound 2; then compounds 3 and 1 (each within the scatter of the next).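

In this assay, the group on a saturated chain carbon bound to an oxygen on an aromatic ring clearly matters: 4-fluorophenyl in place of 3-(trifluoromethyl)phenyl gives a 3.6-fold higher number from compound 2 to compound 3 (0.56 log units; beyond the scatter), towards weaker inhibition. For the compounds shown here, this is the first comparison here of compounds that differ in one place, which compound 1 and compound 2 do not. No measurement at hand gives a reason for this step.

The swap changes both the substituent and its place on the ring, and the compounds shown do not separate the two. On these data alone, how a plain phenyl or a methoxyphenyl would behave here also remains open.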